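Ester extension on the aryl substituent of compound 1

The compounds below may be only part of what the source reports. "The series", "measured", "known", "first", "only" and "open" are said of these compounds alone.

Compound 1 `CCCC[S+]([O-])c1sc2nc(-c3nccs3)cc(-c3ccc(C(=O)OC)cc3)c2c1N` is the starting point. In an assay for inhibition of 15-hydroxyprostaglandin dehydrogenase [NAD(+)] (Homo sapiens), read by fluorescence, with a stated time of 15 min, in the presence of a further agent that is not named here (on this read-out higher numbers stand for weaker inhibition and lower numbers for stronger inhibition), compound 1 gives 15.1 nM, the highest of the two numbers in hand. The nearest is compound 2 `CCCC[S+]([O-])c1sc2nc(-c3nccs3)cc(-c3cnc(Cl)n3C)c2c1N`, which in this assay gives 3.2 nM; the step between them is a 4.7-fold lower number from compound 1 to compound 2 (0.67 log units; beyond the scatter).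

Compound 3 `CCCC[S+]([O-])c1sc2nc(-c3nccs3)cc(-c3ccc(COC(=O)CN(C)C)cc3)c2c1N` is not yet measured. It differs from compound 1 by ((((dimethylamino)methyl)carbonyl)oxy)methyl in place of methoxycarbonyl on an aromatic carbon. Among the compounds with values here, no measured step follows this change. Within the data shown here, the one step available, from compound 1 to compound 2, alters the same aromatic carbon, but it swaps the whole aryl group for a different ring rather than extending the methoxycarbonyl, so it offers no direct guide to the direction or size of the present change. With nothing closer to lean on, the working expectation for compound 3 in this assay is a number close to that of compound 1, with no step beyond the scatter and a wide margin of uncertainty either way. For compound 3 the estimate is 20 nM, within 6 nM to 70 nM. For compound 3 this estimate means an expected step of a 1.3-fold higher number from compound 1 to compound 3 (0.12 log units; within the scatter).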

Compound 3, half-maximal inhibitory concentration: 3.5 nM
Estimate against measurement, compound 3: 5.7-fold (0.76 log units) above; measured number below the stated range.
By their numbers in this assay, from the lowest: compounds 2 and 3 (each within the scatter of the next); then compound 1.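

Working notes: in this assay, the step of a 4.3-fold lower number from compound 1 to compound 3 (0.63 log units; beyond the scatter) shows that the number at this aromatic carbon, para to a large group, responds to a change within the substituent while the six-membered aromatic ring stays in place; the earlier step replaced the whole aryl group and could not show this. The entering ((((dimethylamino)methyl)carbonyl)oxy)methyl has 8 heavy atoms against 4 in methoxycarbonyl, so the larger chain is compatible with a lower number here, and compound 2 at 3.2 nM and compound 3 at 3.5 nM lie within the scatter of each other despite their different groups at this place. No measurement in hand bears on why the number falls with this change.

The change alters the chain length, the ester linkage and the presence of the dimethylamino group all at once, so the part responsible for the step remains unassigned. Going by these compounds, a hydroxymethyl, an acetoxymethyl or a carboxylic acid on the same carbon would help separate these contributions, and the reading of such groups remains open.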